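A Longer, Bulkier Side Chain on the Shared Core

The source may report more compounds than this note shows. Statements on the series, on what has been measured and on what is new or still open speak of the compounds shown alone.

Three related compounds have been measured in a functional assay on A549 cells (Homo sapiens) for antiproliferative activity, read by MTT assay, with a stated time of 48 h; a lower number here means a stronger inhibitor, a higher number a weaker inhibitor. For the measured compounds named here, compound 3 (`CN(C)CCCn1c(N)c(-c2nc3ccccc3n2C)c2nc(C#N)c(C#N)nc21`) gives 11700 nM, the higher of the two exact numbers so far. Compound 1 (`CCN(CC)CCCCn1c(N)c(-c2nc3ccccc3[nH]2)c2nc(C#N)c(C#N)nc21`) gives 5750 nM. Compound 2 (`CN(C)CCn1c(N)c(-c2nc3ccccc3n2C)c2nc(C#N)c(C#N)nc21`) reads > 50000 nM, which is a limit of the assay and not a number.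

The next compound is compound 4 (`CCN(CC)CCCCn1c(N)c(-c2nc3ccccc3n2C)c2nc(C#N)c(C#N)nc21`). Its difference from compound 3 is (diethylamino)methyl in place of dimethylamino on a saturated chain carbon, three bonds along the chain from an aromatic nitrogen: the 3-(dimethylamino)propyl chain becomes a 4-(diethylamino)butyl chain.

One measured step resembles this change. Placing (dimethylamino)methyl where dimethylamino stood, two bonds along the chain from an aromatic nitrogen, gave an at least 4.2-fold lower number from compound 2 to compound 3 (0.63 log units; beyond the scatter). From the compounds shown here alone, that is a single step, and its true size is unknown because one end is a limit, so it indicates a direction more than a size. Compound 1 also carries the 4-(diethylamino)butyl chain, and its value of 5750 nM suggests where compound 4 may land.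

A modest fall in the number is therefore expected in this assay, estimated as a 2.0-fold lower number from compound 3 to compound 4 (0.29 log units; within the scatter). The estimate for compound 4 is 6000 nM, with an expected range of 2500 nM to 14000 nM.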

Compound 4, half-maximal inhibitory concentration: 1720 nM
For compound 4 the middle estimate is 3.5-fold (0.54 log units) above the measured one; the whole stated range lies above it.
By their numbers in this assay, from the lowest: compound 4; then compound 1; then compound 3. At a limit, above all of these: compound 2.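

The change from the 3-(dimethylamino)propyl chain to the 4-(diethylamino)butyl chain gives a 6.8-fold lower number from compound 3 to compound 4 (0.83 log units; beyond the scatter) in this assay, so this chain position clearly affects the number, with a step that is an exact measurement and not one tied to a limit. For the compounds shown here, a second place also comes into view for the first time: with the 4-(diethylamino)butyl chain held constant, methyl in place of hydrogen on an aromatic nitrogen gives a 3.3-fold lower number from compound 1 to compound 4 (0.52 log units; beyond the scatter), showing that this small change on the shared core matters as well. Compound 2 reads > 50000 nM, which is a limit and not a number, so an at least 29-fold lower number from compound 2 to compound 4 (1.46 log units; beyond the scatter) gives only a minimum size for the full change in the side chain: the limit of > 50000 nM in this assay, at which 1 of the 4 values shown sits.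

The chain length and the groups on the amine change together from the 3-(dimethylamino)propyl chain to the 4-(diethylamino)butyl chain, and the compounds shown cannot separate the two contributions. From the compounds shown here alone, a 4-(dimethylamino)butyl chain would help to separate them, while the effect of a still longer chain, or of a piperidine at the chain end, remains open.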